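Swapping one group on compound 1

The compounds below may be only part of what the source reports. "The series", "measured", "known", "first", "only" and "open" are said of these compounds alone.

In a functional assay on DLD-1 cells (Homo sapiens) for cytotoxicity, read by resazurin assay, with a stated time of 48 h (on this read-out higher numbers stand for an effect only at larger amounts of compound and lower numbers for an effect already at smaller amounts), compound 1 (`COc1ccc(S(=O)(=O)Nc2ccc(-c3nc4cc(NS(=O)(=O)c5ccc(OC)cc5)ccc4o3)cc2)cc1`) gives 28000 nM and compound 2 (`O=S(=O)(Nc1ccc(-c2nc3cc(NS(=O)(=O)c4ccc(Cl)s4)ccc3o2)cc1)c1ccc(Cl)c(C(F)(F)F)c1`) gives 22000 nM as its result. These two numbers lie within the usual scatter of repeated measurements, so compound 1 stands level with compound 2 and neither can be ranked ahead of the other. Compound 3 (`COc1ccc(S(=O)(=O)Nc2ccc3oc(-c4ccc(NC(=O)c5cccc(C)c5[N+](=O)[O-])cc4)nc3c2)cc1`) has not been measured yet. It differs from compound 1 in one place, where (3-methyl-2-nitrophenyl)carbonyl stands in place of (4-methoxyphenyl)sulfonyl on a nitrogen on an aromatic ring ((3-methyl-2-nitrophenyl)carbonyl in place of (4-methoxyphenyl)sulfonyl on a nitrogen on an aromatic ring). Within the data shown here, no measured pair here differs in just one place, so nothing yet shows how far a single swap moves the number in this assay on its own. Among the measured compounds shown here, with compound 1 at 28000 nM and compound 2 at 22000 nM as the only guides, no change beyond the scatter is expected in either direction. The estimated step is a 1.4-fold lower number from compound 1 to compound 3 (0.15 log units; within the scatter) and it carries wide uncertainty. Compound 3 is estimated at 20000 nM with 7000 nM to 50000 nM as the expected range.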

Compound 3, half-maximal effective concentration: 1500 nM
Beside the measured number, compound 3's estimate is 13-fold (1.12 log units) above it; the measured number lies below the stated range.
By their numbers in this assay, from the lowest: compound 3; then compounds 2 and 1 (each within the scatter of the next).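

Replacing (4-methoxyphenyl)sulfonyl with (3-methyl-2-nitrophenyl)carbonyl on a nitrogen on an aromatic ring gives a 19-fold lower number from compound 1 to compound 3 (1.27 log units; beyond the scatter) in this assay. This shows that a single swap at this position can move the number well beyond the scatter, which compounds 1 and 2 could not show, since they differ in more than one place. The two groups match in their counts of six-membered aromatic rings, double bonds outside aromatic rings, hydrogen-bond donors and hydrogen-bond acceptors, so those counts do not separate them, and no measurement here explains the step.

The swap changes the sulfonyl link to a carbonyl and also changes what the aromatic ring carries, so the compounds shown leave open how much of the step belongs to each, a question that (4-methoxyphenyl)carbonyl or (3-methyl-2-nitrophenyl)sulfonyl at the same nitrogen would address. Going by these compounds, it also remains open whether the nitro group is needed for the step, or whether an amine in its place, or a plain phenylcarbonyl group, would give a similar number.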